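Compound 1 and its unmeasured ring-carbon stereoisomer

The source may hold more compounds than are shown below. What is called first, only, known or untested is meant among the compounds shown, and "the series" means these compounds.

Measured so far in a functional assay on A549 cells (Homo sapiens) for cytotoxicity, read by MTT assay, with a stated time of 48 h; on this read-out higher numbers stand for weaker inhibition and lower numbers for stronger inhibition:
compound 1 `COc1cc([C@@H]2C[C@@]2(CO)C(=O)Nc2ccccc2)cc(OC)c1OC` gives 43200 nM
compound 2 `COc1cc([C@@H]2C[C@]2(CO)C(=O)Nc2ccccc2Cl)cc(OC)c1OC` gives 4400 nM
compound 3 `CCOC(=O)[C@]1(C(=O)Nc2ccccc2)C[C@H]1c1cc(OC)c(OC)c(OC)c1` gives 37300 nM

Compound 1 (43200 nM) and compound 3 (37300 nM) lie within the scatter of each other, and together they form the high-number end of this small set. Compound 2 (4400 nM) stands beyond the scatter on the lower side of compound 1, so it marks the stronger end.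

Compound 4 `COc1cc([C@H]2C[C@@]2(CO)C(=O)Nc2ccccc2)cc(OC)c1OC` has not been measured. Its relation to compound 1 is a pure change of drawn configuration (the two compounds have the same atoms and bonds and differ only in configuration as drawn: 1 of 2 stereo elements differ; a stereocentre at a saturated ring carbon is drawn S in compound 1 and R in compound 4), with no atom leaving or entering. Going by the values given here, the series holds no measured pair that isolates such a change, so the data give no direct guide to its size.

In this assay the expectation is therefore a small shift at most, probably within the scatter and tilted slightly towards a lower number, as an estimated step (a 1.4-fold lower number from compound 1 to compound 4 (0.16 log units; within the scatter)). The lower end of the range stays wide, since compound 2 at 4400 nM shows that lower numbers are reachable in this series. Compound 4 is expected at 30000 nM (estimated range 10000 nM to 70000 nM).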

Compound 4, half-maximal inhibitory concentration: > 100000 nM
Compound 4 was reported as a limit; the forecaster's own chance of this, stated with the estimate: 10%; middle value at least 3.3-fold (0.52 log units) away from the limit.
By their numbers in this assay, from the lowest: compound 2; then compounds 3 and 1 (each within the scatter of the next). At a limit, above all of these: compound 4.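

In this assay, going by these compounds alone, the change of drawn configuration at the saturated ring carbon from S to R gives an at least 2.3-fold higher number from compound 1 to compound 4 (0.36 log units; beyond the scatter), the first single change that can be read as a step. Compound 4 gives > 100000 nM, which is a limit, so the step has a lower bound and no fixed size. Because nothing else separates the pair, the step belongs to the configuration at this one carbon, and the S form as drawn is the one with measurable cytotoxicity in this pair: the fact that compounds 1 and 4 differ only in the configuration as drawn

From the compounds shown here alone, compound 2 and compound 3 each differ from the other compounds in more than one place, so their steps cannot be read, and whether the same configuration change matters with the chlorine on the anilide ring or with the ethyl ester remains open. Also open, going by these compounds, is whether a carboxylic acid or an amine in place of the hydroxymethyl group would retain the same dependence on configuration at this carbon.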